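This account rests on a few compounds, and the source may have more. Where it says the series, first, only, none or still open, it means among the compounds named here.

Compound 1 `CCO/C(O)=C1\C(COCCNC(C)=O)=NC(C)=C(C(=O)OC)C1c1ccccc1Cl` gives 15.9 nM in a functional assay (aorta) with Rattus norvegicus as the target; on this read-out higher numbers stand for weaker inhibition and lower numbers for stronger inhibition.
Compound 2 `CCO/C(O)=C1\C(COCCNC(=O)c2cnccn2)=NC(C)=C(C(=O)OC)C1c1ccccc1Cl` gives 39.8 nM.
Compound 3 `CCO/C(O)=C1\C(COCCNC(=O)c2ccc(O)nc2)=NC(C)=C(C(=O)OC)C1c1ccccc1Cl` gives 6.31 nM.

Compound 1 has the second highest number of the three: compound 2 sits one step above it, a 2.5-fold higher number from compound 1 to compound 2 (0.40 log units; beyond the scatter), and compound 3 one step below it, a 2.5-fold lower number from compound 1 to compound 3 (0.40 log units; beyond the scatter). Compound 4 `CCO/C(O)=C1\C(COCCNC(=O)NCC(N)=O)=NC(C)=C(C(=O)OC)C1c1ccccc1Cl` differs from compound 1 in one place: (carbamoylmethyl)amino in place of methyl on a carbonyl carbon. Both measured steps from compound 1 change the group on the same carbonyl carbon, and each moved the number only modestly, in opposite directions, so the data show that this position matters but give no clear direction for a (carbamoylmethyl)amino group there. The step is therefore expected to stay small: a 1.3-fold higher number from compound 1 to compound 4 (0.10 log units; within the scatter). Compound 4 is estimated at 20 nM, with a range from 6 nM to 63 nM.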

Compound 4, half-maximal inhibitory concentration: 20 nM
Compound 4: the middle estimate sits on the measured number at the digits printed; the measured number falls inside the stated range.
By their numbers in this assay, from the lowest: compound 3; then compounds 1, 4 and 2 (each within the scatter of the next, the first and the last beyond it).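

A much larger group on this carbonyl carbon is tolerated: (carbamoylmethyl)amino brings 5 heavy atoms in place of the single one of methyl and shows a 1.3-fold higher number from compound 1 to compound 4 (0.10 log units; within the scatter). A ring is therefore not needed to hold this level, as the step from the pyrazin-2-yl group gives a 2.0-fold lower number from compound 2 to compound 4 (0.30 log units; within the scatter), while the step from the 6-hydroxypyridin-3-yl group gives a 3.2-fold higher number from compound 3 to compound 4 (0.50 log units; beyond the scatter). No measurement here accounts for these steps.

Going by these compounds, it remains open how a longer chain ending in a carboxylic acid would behave on this carbonyl carbon. A plain pyridin-3-yl group would show whether the hydroxy group matters for compound 3.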